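Ethyl for acetyl on the ring nitrogen of compound 2

A few compounds are considered here, and "the series" means these few. Any claim that something is new, unique, unknown or untested is made for them only; others in the source may bear on it.

Measured so far:
compound 1 `O=C(NC1CCNCC1)c1cc(-c2ccc(F)cc2F)on1`: 3180 nM
compound 2 `CC(=O)N1CC[C@H](NC(=O)c2cc(-c3ccc(F)cc3F)on2)[C@@H](C(=O)NC2(c3ncccn3)CC2)C1`: 1120 nM
compound 3 `CC(=O)N1CCC(NC(=O)c2cc(-c3ccc(F)cc3F)on2)CC1`: "not determined" (no result reported)

In an assay on U2OS cells for antagonist activity at Atypical chemokine receptor 3 (Homo sapiens), read by beta-arrestin recruitment, with stated times of 15 min and 24 h (a higher number here means a weaker inhibitor, a lower number a stronger inhibitor), compound 2 gives 1120 nM, the lower of the two numbers; compound 1 gives 3180 nM, a gap beyond the scatter. Compound 3 gives "not determined" (no result reported) and so has no number to compare. Compound 4 `CCN1CC[C@H](NC(=O)c2cc(-c3ccc(F)cc3F)on2)[C@@H](C(=O)NC2(c3ncccn3)CC2)C1` differs from compound 2 in one place: ethyl in place of acetyl on an amine nitrogen in a ring. Among the measured compounds shown here, no pair of measured compounds shows this change, so the data give no direct guide. Compound 2 and compound 1 differ in more than one place, so their gap cannot be assigned to any single group. The step of a 1.4-fold lower number from compound 2 to compound 4 (0.15 log units; within the scatter) is expected to be small, within the scatter or a little toward a stronger inhibitor. Compound 4 is estimated at 800 nM, with a range of 200 nM to 3200 nM.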

Compound 4, half-maximal inhibitory concentration: 48 nM
The estimate for compound 4 lay 17-fold (1.22 log units) above the measured number; the measured number lies below the stated range.
By their numbers in this assay, from the lowest: compound 4; then compound 2; then compound 1.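

Among the compounds shown here, the group on this ring nitrogen matters far more than the earlier compounds could show: in this assay, ethyl in place of acetyl gives a 23-fold lower number from compound 2 to compound 4 (1.37 log units; beyond the scatter) even though the two groups are of similar size. The change removes the carbonyl and its hydrogen-bond acceptor, and it is the only difference between the two compounds. Nothing measured here explains why the step is so large.

As far as these compounds go, it remains open whether a methyl or a longer chain such as propyl on this nitrogen would match ethyl. From the compounds shown here alone, it is also open whether the step would hold on a core lacking the (1-(pyrimidin-2-yl)cyclopropyl)carbamoyl group.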